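Three Limits and a Ring Swap on the Amide Nitrogen

A few compounds are considered here, and "the series" means these few. Any claim that something is new, unique, unknown or untested is made for them only; others in the source may bear on it.

In an assay on HEK293 cells for inhibition of transient receptor potential cation channel subfamily M member 8 (Homo sapiens), read by FLIPR and calcium flux (on this read-out lower numbers stand for stronger inhibition and higher numbers for weaker inhibition), compound 1 `CN(C(=O)c1ccccc1OCc1ccccc1)[C@@H]1CCNC1` gives > 10000 nM, which is a limit of the assay rather than a number. Compound 2 `CCN(C(=O)c1ccccc1OCc1ccccc1)C1CCNC1` likewise gives only a limit, > 5000 nM. Compound 3 `O=C(c1ccccc1OCc1ccccc1)N1C[C@H]2CNC[C@H]2C1` also stops at a limit, > 10000 nM. Because every value sits at a limit, the limit of > 10000 nM in this assay, at which 2 of the 3 values shown sit, and (the limit of > 5000 nM in this assay, at which 1 of the 3 values shown sits), the steps a step that the two limits leave unreadable from compound 1 to compound 2, a step that the two limits leave unreadable from compound 1 to compound 3 and a step that the two limits leave unreadable from compound 2 to compound 3 cannot be read. Compound 4 `CN(C(=O)c1ccccc1OCc1ccccc1)[C@@H]1CCC[C@H](N)C1` differs from compound 1 by 3-aminocyclohexyl in place of pyrrolidin-3-yl on an amide-type nitrogen. Among the measured compounds shown here, no measured step bears on this change, so nothing beyond the scatter is expected in this assay; the step of a number no higher from compound 1 to compound 4 (the limit leaves the size open) is estimated as roughly none. Compound 4 is therefore expected at about 10000 nM, within 3000 nM to 30000 nM.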

Compound 4, antagonist equilibrium constant: 3670 nM
Estimate against measurement, compound 4: 2.7-fold (0.44 log units) above; low and high end bracket the measured number.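

In this assay the change to 3-aminocyclohexyl on the amide-type nitrogen brings an at least 2.7-fold lower number from compound 1 to compound 4 (0.43 log units; beyond the scatter) and makes compound 4 the only compound shown with a number rather than a limit. So this position can take a change that moves the read-out beyond the scatter. The full size of the step stays unknown because compound 1 has only a limit and no number of its own: the limit of > 10000 nM in this assay, at which 2 of the 4 values shown sit.

Ring size and the place of the nitrogen change together here, so their separate contributions remain open. Plain cyclohexyl or 3-hydroxycyclohexyl at this position would test whether the amine matters.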